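This account rests on a few compounds, and the source may have more. Where it says the series, first, only, none or still open, it means among the compounds named here.

Measured so far in a functional assay on CRL2813 cells (Homo sapiens) for cytotoxicity, read by sulforhodamine B assay, with a stated time of 5 days; a higher number here means a weaker inhibitor, a lower number a stronger inhibitor:
compound 1 `O=C(Nc1cccc(C(F)(F)F)c1)N[C@H]1CC[C@H](Oc2cccc(C(F)(F)F)c2)CC1`: 1300 nM
compound 2 `O=C(Nc1cccc(C(F)(F)F)c1)N[C@H]1CC[C@@H](Oc2ccc(F)cc2)CC1`: 2600 nM
compound 3 `O=C(Nc1ccc(Cl)cc1)N[C@H]1CC[C@H](Oc2ccc(F)cc2)CC1`: > 20000 nM

Compound 3 stands only at a limit of this assay, > 20000 nM, not at a number; this is the limit of > 20000 nM in this assay, at which 1 of the 3 values shown sits. Compound 4 `COc1ccccc1NC(=O)N[C@H]1CC[C@H](Oc2ccc(F)cc2)CC1` is not yet measured. It differs from compound 3 in one place: 2-methoxyphenyl in place of 4-chlorophenyl on an amide-type nitrogen. Within the data shown here, no step between measured compounds shows what this exchange does, so the expected step from compound 3 to compound 4 is uncertain in direction and is estimated as a number no higher from compound 3 to compound 4 (the limit leaves the size open), which may well stay within the scatter. Compound 4 is therefore expected to give about 20000 nM in this assay, within a range of 6000 nM to 60000 nM, with a fair chance of another limit only.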

Compound 4, half-maximal inhibitory concentration: > 20000 nM
Compound 4: a limit, no number (the forecaster's own chance of this, stated with the estimate: 55%); the middle value sits exactly at the limit.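

Compound 3 and compound 4 both stand at a limit rather than a number, so no step can be read between them: the limit of > 20000 nM in this assay, at which 2 of the 4 values shown sit.

From the compounds shown here alone, whether 2-methoxyphenyl in place of 4-chlorophenyl on an amide-type nitrogen changes the activity at all remains open.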